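A few compounds are considered here, and "the series" means these few. Any claim that something is new, unique, unknown or untested is made for them only; others in the source may bear on it.

Measured compounds in a functional assay (Platelet, plasma) for inhibition, with Homo sapiens as the target; a higher number here means a weaker inhibitor, a lower number a stronger inhibitor:
Compound 1 `N#Cc1cc2c(nc1N1CCC(C(=O)NS(=O)(=O)Cc3ccc(Cl)cc3)CC1)COC2=O` gives 4420 nM.
Compound 2 `Cc1ccc(CS(=O)(=O)NC(=O)C2CCN(c3nc4c(cc3C#N)C(=O)OC4)CC2)cc1` gives 4280 nM.
Compound 3 `N#Cc1cc2c(nc1N1CCC(C(=O)NS(=O)(=O)Cc3cc(Cl)cc(Cl)c3)CC1)COC2=O` gives 30500 nM.

Compound 3 holds the highest number of the three, and its gaps to the other two are beyond the scatter: a 6.9-fold higher number from compound 1 to compound 3 (0.84 log units; beyond the scatter) and a 7.1-fold higher number from compound 2 to compound 3 (0.85 log units; beyond the scatter). Compounds 1 and 2, which carry 4-chlorophenyl and 4-methylphenyl on the saturated chain carbon bound to the sulfonyl sulfur, sit within the scatter of each other, as a 1.0-fold lower number from compound 1 to compound 2 (0.01 log units; within the scatter) shows.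

Compound 4 `N#Cc1ccc(CS(=O)(=O)NC(=O)C2CCN(c3nc4c(cc3C#N)C(=O)OC4)CC2)cc1` is not yet measured. It differs from compound 3 in one place: 4-cyanophenyl in place of 3,5-dichlorophenyl on a saturated chain carbon bound to a sulfonyl sulfur. The two measured steps that bear on this change run from 4-chlorophenyl or 4-methylphenyl to 3,5-dichlorophenyl, and both raised the number by a modest amount. Among the compounds with values here, compound 4 returns to a phenyl carrying one substituent, so the reverse of those steps is the natural guide, though no measured compound carries a 4-cyanophenyl here and the nitrile may not behave like chloro or methyl.

Compound 4 is therefore expected to land near compounds 1 and 2, with an estimated 6000 nM in this assay, in a range from 2500 nM to 15000 nM. The expected step is a 5.1-fold lower number from compound 3 to compound 4 (0.71 log units; beyond the scatter).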

Compound 4, half-maximal inhibitory concentration: 8900 nM
The estimate for compound 4 lay 1.5-fold (0.17 log units) below the measured number; the range from low to high includes it.
By their numbers in this assay, from the lowest: compounds 2, 1 and 4 (each within the scatter of the next, the first and the last beyond it); then compound 3.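

In this assay, a third substituent on the phenyl ring, 4-cyanophenyl in place of 3,5-dichlorophenyl, gives a 3.4-fold lower number from compound 3 to compound 4 (0.53 log units; beyond the scatter), so the advantage over the 3,5-dichlorophenyl compound is no longer confined to chloro and methyl. The nitrile also gives the first separation among the singly substituted phenyl groups: cyano in place of methyl gives a 2.1-fold higher number from compound 2 to compound 4 (0.32 log units; beyond the scatter), a modest step just beyond the scatter, whereas cyano in place of chloro gives a 2.0-fold higher number from compound 1 to compound 4 (0.30 log units; within the scatter), which stays within it. This position therefore accepts all three of these groups on the phenyl ring with only small differences in this assay, and no supporting evidence is available to explain those differences or the gap to compound 3.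

The compounds shown leave open how a phenyl with no substituent, or one carrying a methoxy group or a carboxylic acid, would read in this assay. They also leave open whether the higher number of compound 3 depends on having a second chloro or on where the two chloro groups sit on the ring.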